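Ortho Fluoro Substitution on a Propargylamine Amide Scaffold

The source may report more compounds than this note shows. Statements on the series, on what has been measured and on what is new or still open speak of the compounds shown alone.

Compound 1 `C#CCN(Cc1ccc(OCc2cccc(F)c2)cc1)[C@@H](C)C(N)=O`: 530 nM
Compound 2 `NC(=O)[C@@H]1CCN1Cc1ccc(OCc2cccc(F)c2)cc1Cl`: 35 nM

In an assay on Sf9 cells for inhibition of Amine oxidase [flavin-containing] B (Homo sapiens), with stated times of 15 min and 60 min (on this read-out lower numbers stand for stronger inhibition and higher numbers for weaker inhibition), compound 1 gives 530 nM, the highest of the two numbers, and compound 2 gives 35 nM, a gap beyond the scatter. The two structures differ in several places, so their values are only compared, not attributed. Compound 3 `C#CCN(Cc1ccc(OCc2cccc(F)c2)cc1F)[C@@H](C)C(N)=O` carries fluoro in place of hydrogen on an aromatic carbon, a fluoro in place of hydrogen on an aromatic carbon. Within the data shown here, with no single-change step to guide it, the estimate for compound 3 is 250 nM (range 80 nM to 700 nM), a step of a 2.1-fold lower number from compound 1 to compound 3 (0.33 log units; beyond the scatter) expected to be modest, toward stronger inhibition.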

Compound 3, half-maximal inhibitory concentration: 93 nM
Compound 3: middle estimate off by 2.7-fold (0.43 log units), on the high side, and the stated range covers the measured number.
By their numbers in this assay, from the lowest: compound 2; then compound 3; then compound 1.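

In this assay, fluoro in place of hydrogen on an aromatic carbon, ortho to a large group, gives a 5.7-fold lower number from compound 1 to compound 3 (0.76 log units; beyond the scatter) and is the only single-change step shown. It shows that this position responds to one added fluorine atom, with the number moving toward stronger inhibition beyond the scatter. Nothing shown accounts for the size of this step.

As far as these compounds go, whether a methoxy or trifluoromethyl group at the same place would move the number in the same direction stays open. Also open, from the compounds shown here alone, is whether the step would carry over to the core of compound 2.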